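The source may report more compounds than this note shows. Statements on the series, on what has been measured and on what is new or still open speak of the compounds shown alone.

Measured in an ADME assay on microsomes from liver (Mus musculus) for pharmacokinetics, read by LC-MS, using NADPH, with stated times of 5 min, 15 min and 30 min, tested at 10 uM; on this read-out lower numbers stand for slow clearance and higher numbers for fast clearance:

- Compound 1 `C[C@H](NC(=O)c1ncccn1)c1ccc(NC(=O)N2CC(c3cccnc3)C2)cc1`: 28.9 mL.min-1.g-1
- Compound 2 `C[C@@H](c1ccc(NC(=O)N2CC(c3ccc(N)nc3)C2)cc1)N1Cc2ccccc2C1=O`: < 25 mL.min-1.g-1, a limit
- Compound 3 `C[C@H](NC(=O)c1ncccn1)c1ccc(NC(=O)N2CC(c3ccc(N)nc3)C2)cc1`: < 25 mL.min-1.g-1, a limit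

Compound 3 has no number, only a limit of < 25 mL.min-1.g-1. This is the limit of < 25 mL.min-1.g-1 in this assay, at which 2 of the 3 values shown sit.

Compound 4 `CCC(=O)N[C@@H](C)c1ccc(NC(=O)N2CC(c3ccc(N)nc3)C2)cc1` differs from it by one change, ethyl in place of pyrimidin-2-yl on a carbonyl carbon. Two measured steps reach compound 3. One, an at least 1.1-fold lower number from compound 1 to compound 3 (0.06 log units; that floor lies within the scatter), is amino in place of hydrogen on an aromatic carbon, a different change. The other, a step that the two limits leave unreadable from compound 2 to compound 3, exchanges a larger group that contains the pyrimidin-2-yl, and its size cannot be read. Neither sizes the change to ethyl, so no step beyond the scatter is expected in this assay. The estimated step is a step that the limit leaves unreadable from compound 3 to compound 4. For compound 4 the expected value is 22 mL.min-1.g-1, with an estimated range of 12 mL.min-1.g-1 to 42 mL.min-1.g-1.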

Compound 4, intrinsic clearance in microsomes: 22 mL.min-1.g-1
Compound 4: middle estimate and measured number agree at the digits printed, and the stated range covers the measured number.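

The steps to compound 4 from compound 2 and from compound 3 cannot be read, since both of those compounds carry only a limit: the limit of < 25 mL.min-1.g-1 in this assay, at which 2 of the 4 values shown sit.

The compounds shown leave open how large the change from pyrimidin-2-yl to ethyl is in this assay.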